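Notes on the amine change from compound 2 to compound 3

The compounds below may be only part of what the source reports. "The series", "measured", "known", "first", "only" and "open" are said of these compounds alone.

Measured so far: compound 1 `CCC/C=C/C(=O)Nc1cc2c(N3CCc4ccccc43)ncnc2cc1O[C@@H]1CCOC1` gives 9230 nM in a functional assay on PC-3 cells (Homo sapiens) for antiproliferative activity, read by MTT assay, with a stated time of 72 h; a lower number here means a stronger inhibitor, a higher number a weaker inhibitor; compound 2 `CN(C)C/C=C/C(=O)Nc1cc2c(N3CCc4ccccc43)ncnc2cc1O[C@@H]1CCOC1` gives 1230 nM in this assay.

Among the measured compounds shown here, compound 2 holds the lower of the two numbers; its only neighbour is compound 1, separated by a 7.5-fold lower number from compound 1 to compound 2 (0.88 log units; beyond the scatter). Compound 3 `CN1CCN(C/C=C/C(=O)Nc2cc3c(N4CCc5ccccc54)ncnc3cc2O[C@@H]2CCOC2)CC1` differs from compound 2 by 4-methylpiperazin-1-yl in place of dimethylamino on a saturated chain carbon bound to a double-bonded chain carbon. For the measured compounds named here, the single measured step at this position, a 7.5-fold lower number from compound 1 to compound 2 (0.88 log units; beyond the scatter), concerned a different exchange and cannot be carried over directly, so this change is read as roughly neutral. No shift beyond the scatter is expected in this assay; the expected step is a 1.2-fold lower number from compound 2 to compound 3 (0.09 log units; within the scatter). Compound 3 is estimated at 1000 nM, with a range of 400 nM to 3000 nM.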

Compound 3, half-maximal inhibitory concentration: 4210 nM
Compound 3: the middle estimate sits 4.2-fold (0.62 log units) below what was measured; the measured number lies above the stated range.
By their numbers in this assay, from the lowest: compound 2; then compound 3; then compound 1.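

In this assay, the amines on the saturated chain carbon bound to a double-bonded chain carbon are not interchangeable: a 3.4-fold higher number from compound 2 to compound 3 (0.53 log units; beyond the scatter) shows that 4-methylpiperazin-1-yl does not match dimethylamino. The ring amine still improves on ethyl, with a 2.2-fold lower number from compound 1 to compound 3 (0.34 log units; beyond the scatter) as its step, so both amines give lower numbers than ethyl, but by unequal steps. Nothing available explains the gap between the two amines.

Open, as far as these compounds go, is whether morpholine, piperidine or diethylamino at this place would read closer to dimethylamino or to 4-methylpiperazin-1-yl.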